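Clearance at the Limit as a Ring Enters the Chain

This account rests on a few compounds, and the source may have more. Where it says the series, first, only, none or still open, it means among the compounds named here.

In an in vitro ADME assay on microsomes from liver (Mus musculus) for metabolic stability, tested at 0.2 uM (on this read-out higher numbers stand for fast clearance and lower numbers for slow clearance), compound 1 (`CCCCCCCCCc1[nH]c2ccccc2c(=O)c1C`) gives > 1000 mL/min/kg as a limit of the assay, not a number. Compound 2 (`CCCCOc1cccc(OCc2[nH]c3ccccc3c(=O)c2C)c1`) likewise gives > 1000 mL/min/kg as a limit. Compound 3 (`COC(C)(C)CCOc1cccc(OCc2[nH]c3ccccc3c(=O)c2C)c1`) stands at > 1000 mL/min/kg and this too is only a limit. The measured series therefore comes down to one observation: the limit of > 1000 mL/min/kg in this assay, at which 3 of the 3 values shown sit.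

Compound 4 (`Cc1c(COc2cccc(OCC3CCOCC3)c2)[nH]c2ccccc2c1=O`) differs from compound 3 by oxan-4-yl in place of 2-methoxy-2-methylpropyl on a saturated chain carbon bound to an oxygen on an aromatic ring. Going by the values given here, the one measured step on this chain is a step that the two limits leave unreadable from compound 2 to compound 3 and it offers no size to carry over. With every value for compound 1, compound 2 and compound 3 at the same limit, only a modest fall in this assay is expected, and even that is uncertain. The estimated change is an at least 1.2-fold lower number from compound 3 to compound 4 (0.09 log units; that floor lies within the scatter) and it may prove unreadable. For compound 4 the expected clearance is 800 mL/min/kg (estimated range 300 mL/min/kg to 1500 mL/min/kg) and the reading may again be only a limit.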

Compound 4, clearance: 420 mL/min/kg
For compound 4 the middle estimate is 1.9-fold (0.28 log units) above the measured one, and the stated range covers the measured number.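

Going by these compounds alone, compound 4 gives the first readable step: in this assay, oxan-4-yl in place of 2-methoxy-2-methylpropyl on a saturated chain carbon bound to an oxygen on an aromatic ring gives an at least 2.3-fold lower number from compound 3 to compound 4 (0.37 log units; beyond the scatter), and oxan-4-yl in place of propyl at that place gives an at least 2.3-fold lower number from compound 2 to compound 4 (0.37 log units; beyond the scatter). Both groups that differ between compound 3 and compound 4 hold the same count of carbon and oxygen atoms, so this exchange of an open chain for a six-membered non-aromatic ring leaves that count unchanged and still brings the value down from the limit. The earlier compounds could not show this, since the one step among them cannot be read, and compound 4 alone stands apart from the rest: the limit of > 1000 mL/min/kg in this assay, at which 3 of the 4 values shown sit.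

From the compounds shown here alone, the full size of both steps stays open, since each starts from a limit. The compounds shown also cannot separate the ring from its oxygen, which a cyclohexyl or a piperidin-4-yl group at the same place would bear on.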